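From methoxy to methylcarbamoyl on compound 1

The compounds below may be only part of what the source reports. "The series", "measured", "known", "first", "only" and "open" are said of these compounds alone.

In an ADME assay on S9 fraction from liver (Rattus norvegicus) for metabolic stability, with a stated time of 1 h (a lower number here means that less of the compound is left, a higher number that more of the compound is left), compound 1 `CO[C@H]1CC[C@@H](Nc2cc(NCc3cnccc3C(F)(F)F)ncc2C#N)CC1` gives 1% and stands lowest of the two measured numbers. Compound 2 `N#Cc1cnc(NCc2ccccc2C(F)(F)F)cc1N[C@H]1C[C@H](C(N)=O)C1` gives 54% and lies higher, beyond the scatter. Compound 3 `CNC(=O)[C@H]1CC[C@@H](Nc2cc(NCc3cnccc3C(F)(F)F)ncc2C#N)CC1` keeps the core of compound 1 but carries methylcarbamoyl in place of methoxy on a saturated ring carbon. For the measured compounds named here, no measured pair isolates this change. A rise in this assay beyond the scatter is expected, with compound 2 at 54% as a loose guide for its amide on a saturated ring, though it also differs elsewhere. The estimated change is a number 21 percentage points higher from compound 1 to compound 3 (beyond the scatter) at the middle of the range. For compound 3 the estimate is 22% within a range from 5% to 55% overall.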

Compound 3, percent of the compound remaining: 53%
Estimate against measurement, compound 3: 31 percentage points below; measured number inside the range.
By their numbers in this assay, from the lowest: compound 1; then compounds 3 and 2 (each within the scatter of the next).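

On the saturated ring carbon of the six-membered ring, with the rest of compound 1 kept, methylcarbamoyl in place of methoxy gives a number 52 percentage points higher from compound 1 to compound 3 (beyond the scatter) in this assay. This single change is therefore enough to produce a large step at this position. Nothing at hand explains the step.

Which part of methylcarbamoyl carries the step remains open: the carbonyl, the amide hydrogen or the methyl. A carboxylic acid or a dimethylamine on the same ring carbon would show how far the step extends to other groups.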